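The compounds below may be only part of what the source reports. "The series", "measured", "known", "first", "only" and "open" are said of these compounds alone.

Values in a physicochemical assay for solubility, read by LC-MS, in phosphate buffer, with a stated time of 24 h, at pH 7.4; a higher number here means a more soluble compound, a lower number a less soluble compound:
- compound 1 `CN(c1ccn(C)n1)c1cnc(NCc2c(F)ccc3c2CCO3)n2cnnc12`: 130000 nM
- compound 2 `O=C(Nc1cnc(NCc2c(F)ccc3c2CCO3)n2cnnc12)c1cccnc1`: 12000 nM
- compound 3 `CN(c1cccnc1)c1cnc(NCc2c(F)ccc3c2CCO3)n2cnnc12`: not yet measured

Of the two measured compounds, compound 2 stands lower at 12000 nM, while compound 1 reads 130000 nM. The next structure swaps one group on an aromatic carbon of the shared core, with methyl(pyridin-3-yl)amino in place of ((pyridin-3-yl)carbonyl)amino on an aromatic carbon. Among the compounds with values here, only one measured step bears on this swap: an 11-fold lower number from compound 1 to compound 2 (1.03 log units; beyond the scatter), a large change, in which ((pyridin-3-yl)carbonyl)amino replaced methyl(1-methyl-1H-pyrazol-3-yl)amino. Compound 3 returns to a methyl-bearing amino group like that of compound 1, but with a different aromatic ring. A single step is thin evidence, so only part of that drop is expected to reverse. The expected change is a 5.0-fold higher number from compound 2 to compound 3 (0.70 log units; beyond the scatter). For compound 3 the estimated value is 60000 nM, with an expected range of 20000 nM to 150000 nM.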

Compound 3, solubility: 47000 nM
Compound 3: middle estimate off by 1.3-fold (0.11 log units), on the high side; low and high end bracket the measured number.
By their numbers in this assay, from the lowest: compound 2; then compound 3; then compound 1.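

In this assay, the step with the pyridin-3-yl ring held constant isolates the link to the shared core: methyl(pyridin-3-yl)amino in place of ((pyridin-3-yl)carbonyl)amino gives a 3.9-fold higher number from compound 2 to compound 3 (0.59 log units; beyond the scatter). The ring on the nitrogen also matters, with pyridin-3-yl in place of 1-methyl-1H-pyrazol-3-yl giving a 2.8-fold lower number from compound 1 to compound 3 (0.44 log units; beyond the scatter), so the large earlier drop combined two changes that can now be read separately, each beyond the usual scatter. No measurement here explains either step.

The compounds shown do not tell whether the methyl on the nitrogen contributes, which an ethyl group or a plain hydrogen there would test. Going by these compounds, how a phenyl ring or a saturated ring such as piperidine would compare with pyridin-3-yl also remains open.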